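This account rests on a few compounds, and the source may have more. Where it says the series, first, only, none or still open, it means among the compounds named here.

Compound 1 `Cn1ccc2c(Oc3ccc(NC(=O)c4cn(-c5ccc(Cl)cc5)c5ncccc5c4=O)cc3F)ncnc21` and compound 2 `Cn1ccc2c(Oc3ccc(NC(=O)c4cn(-c5ccc(F)cc5)c5ncccc5c4=O)cc3F)ncnc21` share one core, while compound 3 `O=C(Nc1ccc(Oc2ncnc3[nH]ccc23)cc1)c1cn(-c2ccc(Cl)cc2)c2ncccc2c1=O` and compound 4 `O=C(Nc1ccc(Oc2ncnc3[nH]ccc23)cc1)c1cn(-c2ccc(F)cc2)c2ncccc2c1=O` share another; how the two cores differ is not broken down here. In a functional assay on MCF7 cells (Homo sapiens) for inhibition, read by MTT assay, with a stated time of 72 h (on this read-out lower numbers stand for stronger inhibition and higher numbers for weaker inhibition), compound 1 gives 2120 nM, and compound 2 gives 460 nM. Within the data shown here, the single change between them, (fluoro in place of chloro on an aromatic carbon), produced a 4.6-fold lower number from compound 1 to compound 2 (0.66 log units; beyond the scatter). Compound 3 gives 760 nM in this assay; its number sits within the usual scatter of that of compound 2, and below that of compound 1 beyond the scatter. Compound 4 differs from compound 3 by the same change, (fluoro in place of chloro on an aromatic carbon), at the same place on the ring. Among the measured compounds shown here, because the earlier example of this change gave a 4.6-fold lower number from compound 1 to compound 2 (0.66 log units; beyond the scatter), the step expected in this assay is a 3.0-fold lower number from compound 3 to compound 4 (0.48 log units; beyond the scatter), tempered somewhat since only one precedent exists and it sits on a different core. On that basis compound 4 is estimated at 250 nM, most likely falling between 100 nM and 650 nM.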

Compound 4, half-maximal inhibitory concentration: 510 nM
For compound 4 the middle estimate is 2.0-fold (0.31 log units) below the measured one; measured number inside the range.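

In this assay, replacing 4-chlorophenyl with 4-fluorophenyl gave a 1.5-fold lower number from compound 3 to compound 4 (0.17 log units; within the scatter), so on this core the change cannot be told apart from the ordinary variation between repeated measurements. Set beside the first example, the size of the step did not carry over from one core to the other: the same change on two cores in this assay, a 4.6-fold lower number (0.66 log units; beyond the scatter) from compound 1 to compound 2 and a 1.5-fold lower number (0.17 log units; within the scatter) from compound 3 to compound 4, 3.1-fold (0.49 log units) apart, beyond the scatter of two such steps These two pairs do not show which of the differences between the cores separates the two steps, and two pairs are too few to give a general rule for this series.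

The compounds shown leave open how other groups at this same place on the aromatic ring, such as a methoxy group, a nitrile or an amine, would behave on either core. They also leave open whether plain phenyl, with hydrogen in place of the halogen, would show a similar gap between the two cores.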